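This account rests on a few compounds, and the source may have more. Where it says the series, first, only, none or still open, it means among the compounds named here.

Compound 1, `CC(C)[C@H](NC(=O)COc1cccc2ccccc12)C(=O)N[C@@H](CC(=O)O)C(=O)COc1ccccc1C(F)(F)F`, gives > 100000 nM in a functional assay on Jurkat cells (Homo sapiens); a higher number here means a weaker inhibitor, a lower number a stronger inhibitor.
Compound 2, `CC(C)[C@H](NC(=O)COc1cccc2ccccc12)C(=O)N[C@@H](CC(=O)O)C(=O)COc1ccc([N+](=O)[O-])cc1`, gives > 100000 nM in this assay.
Compound 3, `CC(C)[C@H](NC(=O)COc1cccc2ccccc12)C(=O)N[C@@H](CC(=O)O)C(=O)COc1cc(F)ccc1F`, gives > 100000 nM in this assay.

Each of these three values is a limit of this assay and not a number: no inhibition strong enough to yield a figure was seen. Compound 3 therefore stands at the limit, and the other two compounds stand there as well. For that reason the steps among them carry no readable size: a step that the two limits leave unreadable from compound 1 to compound 2, a step that the two limits leave unreadable from compound 1 to compound 3 and a step that the two limits leave unreadable from compound 2 to compound 3. Nothing in these steps shows whether swapping one phenyl ring for another moves the read-out at all.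

Compound 4, `CC(C)[C@H](NC(=O)COc1cccc2ccccc12)C(=O)N[C@@H](CC(=O)O)C(=O)COc1c(F)c(F)cc(F)c1F`, has not yet been measured in this assay. It differs from compound 3 in one place: 2,3,5,6-tetrafluorophenyl in place of 2,5-difluorophenyl on an oxygen on a saturated carbon. The change leaves 2,5-difluorophenyl and brings in 2,3,5,6-tetrafluorophenyl on the oxygen on a saturated carbon. Among the compounds with values here, no measured step involves the tetrafluorophenyl group, so none bears directly on it. Within the data shown here, because of the limit of > 100000 nM in this assay, at which 3 of the 3 values shown sit, the most likely outcome is that compound 4 also returns only a limit, with no step readable beyond the scatter. Compound 4 is estimated at 150000 nM, within a range from 30000 nM to 1000000 nM. The expected step is a step that the limit leaves unreadable from compound 3 to compound 4.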

Compound 4, half-maximal inhibitory concentration: 4500 nM
Beside the measured number, compound 4's estimate is 33-fold (1.52 log units) above it, and the stated range ends above it.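

At the aryl group on the oxygen on a saturated carbon, the choice of ring can clearly move the read-out in this assay, which the earlier limits could not show: 2,3,5,6-tetrafluorophenyl in place of 2,5-difluorophenyl gives an at least 22-fold lower number from compound 3 to compound 4 (1.34 log units; beyond the scatter), in place of 4-nitrophenyl it gives an at least 22-fold lower number from compound 2 to compound 4 (1.34 log units; beyond the scatter), and in place of 2-(trifluoromethyl)phenyl it gives an at least 22-fold lower number from compound 1 to compound 4 (1.34 log units; beyond the scatter). Each of these sizes is only a minimum, as each step starts from a limit of the assay and not from a number. Compound 4 is the only compound here that yields a real figure, and the change from compound 3 is just two more fluorine atoms on the same ring, so a small edit at this position separates a figure from a limit: the limit of > 100000 nM in this assay, at which 3 of the 4 values shown sit.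

The steps among compounds 1, 2 and 3 stay unreadable, so the rings at the limit cannot be ranked against one another. Going by these compounds, with a single figure, it remains open whether the count of fluorine atoms or their places on the ring matters, and a 2,3,5-trifluorophenyl or pentafluorophenyl group would help to separate the two.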